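Removing the chloro from the benzyloxy arm

The source may hold more compounds than are shown below. What is called first, only, known or untested is meant among the compounds shown, and "the series" means these compounds.

All three measured compounds share one core and differ only in the aryl group on an amide-type nitrogen. Compound 1 `O=C(Nc1cccc(F)c1)Nc1cc2ncncc2cc1OCc1cccc(Cl)c1` gives 7800 nM in a functional assay on GBM2 cells (Homo sapiens) for antiproliferative activity, read by WST assay, with a stated time of 72 h; a lower number here means a stronger inhibitor, a higher number a weaker inhibitor. Compound 2 `O=C(Nc1ccccc1F)Nc1cc2ncncc2cc1OCc1cccc(Cl)c1` gives 4400 nM in this assay, and compound 3 `O=C(Nc1ccc(C(F)(F)F)cc1)Nc1cc2ncncc2cc1OCc1cccc(Cl)c1` gives 4700 nM. The three numbers lie close together: a 1.8-fold lower number from compound 1 to compound 2 (0.25 log units; within the scatter), a 1.7-fold lower number from compound 1 to compound 3 (0.22 log units; within the scatter) and a 1.1-fold higher number from compound 2 to compound 3 (0.03 log units; within the scatter). Compound 3 therefore stands within the scatter of both others, set apart neither from compound 1 nor from compound 2.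

Compound 4 `O=C(Nc1ccc(C(F)(F)F)cc1)Nc1cc2ncncc2cc1OCc1ccccc1` keeps the 4-(trifluoromethyl)phenyl of compound 3 and alters the other arm: hydrogen in place of chloro on an aromatic carbon. The (3-chlorobenzyl)oxy group of compound 3 becomes a plain benzyloxy group.

Among the compounds with values here, no measured step touches this arm; all three vary the aryl group on the amide-type nitrogen, and those swaps moved the numbers only within the scatter. So no measured step bears directly on the chloro-to-hydrogen change, and the unrelated steps give no ground to expect a large effect in either direction. The expected step of a 1.2-fold higher number from compound 3 to compound 4 (0.07 log units; within the scatter) stays within the scatter. The uncertainty is wider than usual; nothing measured tests this position. Compound 4 is estimated at 5500 nM in this assay, in a range from 2000 nM to 15000 nM.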

Compound 4, half-maximal inhibitory concentration: 8600 nM
Estimate against measurement, compound 4: 1.6-fold (0.19 log units) below; measured number inside the range.
By their numbers in this assay, from the lowest: compounds 2, 3, 1 and 4 (each within the scatter of the next).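

In this assay, within the data shown here, hydrogen in place of chloro on this aromatic carbon gives a 1.8-fold higher number from compound 3 to compound 4 (0.26 log units; within the scatter), the first measured step on the benzyloxy arm rather than on the aryl group of the amide-type nitrogen. With the 4-(trifluoromethyl)phenyl group held fixed, the plain benzyloxy group of compound 4 therefore cannot be told apart from the (3-chlorobenzyl)oxy group of compound 3, so this chloro makes no difference that can be read in this assay. The available evidence offers no explanation of how this position behaves.

As far as these compounds go, it remains open whether a different group on this aromatic carbon, such as an amine, a methoxy group or a carboxylic acid, would give a step beyond the scatter. It is also open whether hydrogen in place of chloro would give a similar step alongside the 2-fluorophenyl group of compound 2 or the 3-fluorophenyl group of compound 1, since this change is shown with only one aryl group on the amide-type nitrogen.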